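From 3,4-Difluorophenyl to 4-Chlorophenyl on the Amide Nitrogen

This account rests on a few compounds, and the source may have more. Where it says the series, first, only, none or still open, it means among the compounds named here.

In a functional assay on CCRF-CEM cells (Homo sapiens) for inhibition, read by MTT assay, with a stated time of 72 h (on this read-out lower numbers stand for stronger inhibition and higher numbers for weaker inhibition), compound 1 (`C=C(Br)C(=O)Nc1cccc(/C=C/C(=O)Nc2ccc(F)cc2)c1`) gives 16600 nM and compound 2 (`C=C(Br)C(=O)Nc1cccc(/C=C/C(=O)Nc2ccc(F)c(F)c2)c1`) gives 13 nM as the lower of the two numbers. Compound 3 (`C=C(Br)C(=O)Nc1cccc(/C=C/C(=O)Nc2ccc(Cl)cc2)c1`) has not yet been measured. It differs from compound 2 by 4-chlorophenyl in place of 3,4-difluorophenyl on an amide-type nitrogen. Within the data shown here, only one measured step bears on this change: a 1300-fold lower number from compound 1 to compound 2 (3.11 log units; beyond the scatter) is large and beyond the scatter, for fluoro in place of hydrogen on an aromatic carbon, and compound 3 carries no such added fluoro, so a higher number is expected. Chloro appears in no measured compound, so the size of the rise remains uncertain. The expected step is a 31-fold higher number from compound 2 to compound 3 (1.49 log units; beyond the scatter) and is estimated to be large, yet smaller than the measured one. For compound 3 the estimate is 400 nM (expected range 30 nM to 12000 nM).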

Compound 3, half-maximal inhibitory concentration: 460 nM
Compound 3: middle estimate off by 1.2-fold (0.06 log units), on the low side; measured number inside the range.
By their numbers in this assay, from the lowest: compound 2; then compound 3; then compound 1.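

In this assay, a single chlorine does not make up for the loss of the 3,4-difluorophenyl group on the amide-type nitrogen (a 35-fold higher number from compound 2 to compound 3 (1.55 log units; beyond the scatter)). Yet the identity of the lone halogen matters a great deal at this position: chloro in place of fluoro on an aromatic carbon brings a large gain (a 36-fold lower number from compound 1 to compound 3 (1.56 log units; beyond the scatter)), so a ring with one halogen need not read as poorly as compound 1 does. Nothing given here accounts for either step.

On these data alone, it remains open whether 3,4-dichlorophenyl would match or pass compound 2, and how an unsubstituted phenyl or a ring carrying methoxy or nitrile would read. As far as these compounds go, the three compounds also share the rest of the core of compound 1, so it is unknown whether these steps would hold with a different group there.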